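The compounds below may be only part of what the source reports. "The series", "measured", "known", "first", "only" and "open" are said of these compounds alone.

The compounds share one core, seen in compound 1 `CN(c1ncccc1CNc1nc(Nc2ccc3c(c2)CC(=O)N3)nc2[nH]ccc12)S(C)(=O)=O`, and were tested in a functional assay on SMMC-7721 cells (Homo sapiens) for inhibition, read by MTT assay, with a stated time of 48 h (on this read-out higher numbers stand for weaker inhibition and lower numbers for stronger inhibition), where compound 1 gives 52800 nM. For the measured compounds named here, compound 2 `CN(c1ncccc1CNc1nc(Nc2ccc3c(c2)CC(=O)N3)nc2[nH]cc(Cl)c12)S(C)(=O)=O` gives 21900 nM, and the change a 2.4-fold lower number from compound 1 to compound 2 (0.38 log units; beyond the scatter) is the only measured step with a number at both ends. Compound 3 `CN(c1ncccc1CNc1nc(Nc2ccccc2)nc2[nH]cc(F)c12)S(C)(=O)=O` carries a plain anilino group and a fluorine on the core. For compound 3 this assay reports only a limit, > 100000 nM, so its true value is not known as a number. That limit is described by the limit of > 100000 nM in this assay, at which 1 of the 3 values shown sits.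

Compound 4 `COc1ccc(Nc2nc(NCc3cccnc3N(C)S(C)(=O)=O)c3c(F)c[nH]c3n2)cc1OC` differs from compound 3 by 3,4-dimethoxyphenyl in place of phenyl on a nitrogen on an aromatic ring. Going by the values given here, no measured step touches this part of the molecule: the step from compound 1 to compound 2 changes the core, not the anilino group, so it gives no guide to the direction or size of the effect. With compound 3 sitting at a limit, the expected step of an at least 1.2-fold lower number from compound 3 to compound 4 (0.09 log units; that floor lies within the scatter) cannot be anchored, and it is estimated that compound 4 gives about 80000 nM in this assay, within a range from 20000 nM to 300000 nM, with a real chance that only a limit is reported again.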

Compound 4, half-maximal inhibitory concentration: 54800 nM
Compound 4: the middle estimate sits 1.5-fold (0.16 log units) above what was measured; measured number inside the range.
By their numbers in this assay, from the lowest: compound 2; then compounds 1 and 4 (each within the scatter of the next). At a limit, above all of these: compound 3.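

This is the only step shown on the anilino part of the molecule rather than on the core: in this assay, 3,4-dimethoxyphenyl in place of phenyl gives an at least 1.8-fold lower number from compound 3 to compound 4 (0.26 log units; that floor lies within the scatter). That floor lies within the scatter and so does not by itself establish a gain, yet compound 4 gives a measured number where compound 3 does not. Compound 3 stands only at a limit, so the true size of this step remains unknown: the limit of > 100000 nM in this assay, at which 1 of the 4 values shown sits.

The compounds shown leave open whether a single methoxy group would read like the two together, and how an amine or a carboxylic acid on this phenyl ring would read. The fluorine and the chloro on the core also stay uncompared, with no pair shown that differs in that one place.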